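Adding a Chloro to the Phenyl Ring of Compound 3

The source may hold more compounds than are shown below. What is called first, only, known or untested is meant among the compounds shown, and "the series" means these compounds.

Three measured compounds share one core and differ only in the group attached to the carbonyl carbon of the amide. In an assay on LtK cells with ATP-sensitive inward rectifier potassium channel 11 (Homo sapiens) as the target (on this read-out lower numbers stand for an effect already at smaller amounts and higher numbers for an effect only at larger amounts of compound), compound 1 `CC(=O)Nc1c(C(O)(C(F)(F)F)C(F)(F)F)ccc2ccccc12` gives 18 nM. Compound 2 `O=C(Nc1c(C(O)(C(F)(F)F)C(F)(F)F)ccc2ccccc12)C1CCCC1` gives 495 nM in this assay. Compound 3 `O=C(Nc1c(C(O)(C(F)(F)F)C(F)(F)F)ccc2ccccc12)c1ccccc1` gives 44 nM in this assay, placing it second highest of the three: a 2.4-fold higher number from compound 1 to compound 3 (0.39 log units; beyond the scatter), while an 11-fold lower number from compound 2 to compound 3 (1.05 log units; beyond the scatter). Compound 4 `O=C(Nc1c(C(O)(C(F)(F)F)C(F)(F)F)ccc2ccccc12)c1ccc(Cl)cc1` differs from compound 3 by a single change: chloro in place of hydrogen on an aromatic carbon. Neither measured step touches the phenyl ring itself; both swap the whole group on the carbonyl carbon, so they show how much that choice matters but say nothing about a chloro placed on a phenyl that is already present. Without a direct precedent, the expected step is one within the scatter, a 1.1-fold lower number from compound 3 to compound 4 (0.04 log units; within the scatter). Compound 4 is therefore estimated at 40 nM in this assay, with a range from 12 nM to 130 nM.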

Compound 4, half-maximal effective concentration: 570 nM
Compound 4: middle estimate off by 14-fold (1.15 log units), on the low side; the measured number lies above the stated range.
By their numbers in this assay, from the lowest: compound 1; then compound 3; then compounds 2 and 4 (each within the scatter of the next).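

Among these compounds, the position para to a large group on the phenyl ring of compound 3 is far from indifferent in this assay: a chloro in place of one hydrogen gives a 13-fold higher number from compound 3 to compound 4 (1.11 log units; beyond the scatter), so a single added atom can matter here, whereas the earlier steps each exchanged a whole group. The advantage that phenyl held over cyclopentyl is gone once this chloro is present (a 1.2-fold higher number from compound 2 to compound 4 (0.06 log units; within the scatter)), and the distance to the small methyl amide is wide (a 32-fold higher number from compound 1 to compound 4 (1.50 log units; beyond the scatter)). Nothing available explains why this one atom has so large an effect.

On these data alone, whether a fluoro, a methyl or a methoxy at this same carbon would give a similar step remains open. So does whether a chloro on another carbon of the ring would do the same.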